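Methoxy in place of methyl on a growth inhibitor

The source may report more compounds than this note shows. Statements on the series, on what has been measured and on what is new or still open speak of the compounds shown alone.

Measured so far in a functional assay on NCI-H520 cells (Homo sapiens) for cytotoxicity (a lower number here means a stronger inhibitor of growth, a higher number a weaker inhibitor of growth), are these compounds
- Compound 1 `COc1ccc(C2=C(c3ccc(SC)cc3)CC3CCCN3C2=O)cc1OC(=O)CNC(=O)OC(C)(C)C` gives 7000 nM
- Compound 2 `COc1ccc(C2=C(c3ccc(SC)cc3)CC3CCCN3C2=O)cc1Br` gives 700 nM
- Compound 3 `COc1ccc(C2=C(c3ccc(SC)cc3)CC3CCCN3C2=O)cc1C` gives 100 nM

Compound 3 holds the lowest number of the three, and its steps to both others lie beyond the scatter. Compound 4 `COc1ccc(C2=C(c3ccc(SC)cc3)CC3CCCN3C2=O)cc1OC` is still unmeasured. It differs from compound 3 by methoxy in place of methyl on an aromatic carbon (methoxy in place of methyl on an aromatic carbon, ortho to a methoxy group and meta to a large group). The measured compounds differ only at this same carbon. Putting methyl in place of bromo gave a 7.0-fold lower number from compound 2 to compound 3 (0.85 log units; beyond the scatter) (a modest step), and putting methyl in place of the much larger group gave a 70-fold lower number from compound 1 to compound 3 (1.85 log units; beyond the scatter) (a large one). Methoxy has not been tried at this carbon, so these steps offer only a frame. Compound 2 at 700 nM and compound 1 at 7000 nM both stand higher than compound 3 does. A modest rise in this assay is therefore expected. The expected change is a 2.5-fold higher number from compound 3 to compound 4 (0.40 log units; beyond the scatter) (an estimate, not a measurement). For compound 4 the estimated value is 250 nM (expected range 60 nM to 1000 nM).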

Compound 4, concentration for 50% growth inhibition: 2000 nM
Estimate against measurement, compound 4: 8.0-fold (0.90 log units) below; the whole stated range lies below it.
By their numbers in this assay, from the lowest: compound 3; then compound 2; then compound 4; then compound 1.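

In this assay, methoxy at this carbon proves far less tolerated than methyl, giving a 20-fold higher number from compound 3 to compound 4 (1.30 log units; beyond the scatter) even though the two groups are close in size. Methoxy also falls behind bromo, with a 2.9-fold higher number from compound 2 to compound 4 (0.46 log units; beyond the scatter) on that swap, but it beats the much larger group, with a 3.5-fold lower number from compound 1 to compound 4 (0.54 log units; beyond the scatter) in that comparison, so compound 1 and compound 4, the two compounds with an oxygen on this carbon, now hold the two highest numbers. Nothing measured here explains what that oxygen does.

An ethyl group, a hydroxyl or an amine at this carbon would help separate the effect of the oxygen from that of a longer group. Going by these compounds, the rest of the core stays fixed throughout, so whether methyl keeps its lead when other parts change remains open.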